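This account rests on a few compounds, and the source may have more. Where it says the series, first, only, none or still open, it means among the compounds named here.

Compound 1 `CC(C)(C)N(Cc1ccc([N+](=O)[O-])cc1)C(=O)COC(=O)c1ccc([N+](=O)[O-])o1` is read in an ADME assay on MT4 cells (Homo sapiens) for cytotoxicity, read by MTT assay, with a stated time of 3 days (a higher number here means that more compound is tolerated, a lower number that less compound is tolerated), only as a limit: compound 1 gives > 100000 nM. Compound 2 `CC(=O)Oc1ccccc1CN(C(=O)COC(=O)c1ccc([N+](=O)[O-])o1)C(C)(C)C` carries 2-acetoxyphenyl in place of 4-nitrophenyl on a saturated chain carbon bound to an amide-type nitrogen. In this assay compound 2 likewise gives only a limit, > 100000 nM. Both values sit at the limit of > 100000 nM in this assay, at which 2 of the 2 values shown sit, so the step that the two limits leave unreadable from compound 1 to compound 2 cannot be sized.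

Compound 3 `CC(C)(C)N(Cc1ccc(OCc2ccccc2)cc1)C(=O)COC(=O)c1ccc([N+](=O)[O-])o1` differs from compound 1 by benzyloxy in place of nitro on an aromatic carbon. Going by the values given here, no measured step bears on this change: the only step so far replaces a different group and is itself unreadable. The series therefore offers no ground for a shift beyond the scatter, and the expectation is that compound 3 again comes out at the limit, an estimated step of a number no higher from compound 1 to compound 3 (the limit leaves the size open). Compound 3 is accordingly expected at 100000 nM, within a range of 40000 nM to 250000 nM.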

Compound 3, half-maximal cytotoxic concentration: "not active" (no number reported)
Compound 3: no number reported, so the estimate cannot be set against anything.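

Going by these compounds alone, compound 3 is reported in this assay only as "not active", without a number, and no step from compound 1 to compound 3 can be read. The compounds shown leave open whether benzyloxy in place of nitro changes tolerance at all, and where the actual half-maximal cytotoxic concentrations of compound 1 and compound 3 lie.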